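This account rests on a few compounds, and the source may have more. Where it says the series, first, only, none or still open, it means among the compounds named here.

Measured so far:
Compound 1 `COc1ccccc1/C=C1\CCC/C(=C\c2ccc(OC)c(OC)c2)C1=O`: 8000 nM
Compound 2 `COc1ccc(/C=C2\CCC/C(=C\c3cc(Cl)cc(Cl)c3)C2=O)cc1OC`: 3800 nM

Among the measured compounds shown here, in a functional assay on MCF7 cells (Homo sapiens) for cytotoxicity, read by MTT assay, with a stated time of 72 h (on this read-out higher numbers stand for weaker inhibition and lower numbers for stronger inhibition), compound 2 gives 3800 nM, the lower of the two numbers so far, which means the stronger inhibition of the pair. Compound 3 `COc1ccc(/C=C2\CCC/C(=C\c3ccc(O)c(Cl)c3)C2=O)cc1OC` keeps the rest of compound 2 and changes one group: 3-chloro-4-hydroxyphenyl in place of 3,5-dichlorophenyl on a double-bonded chain carbon bound to a double-bonded ring carbon. For the measured compounds named here, only one measured step bears on this place, a swap of a different pair of groups, and it gave a 2.1-fold lower number from compound 1 to compound 2 (0.32 log units; beyond the scatter). That single modest step is thin evidence, and it says nothing about a hydroxyl group, so no direction can be firmly expected. A step no larger than that one, and probably inside the usual scatter, seems the most likely outcome. The estimated step is a 1.3-fold lower number from compound 2 to compound 3 (0.10 log units; within the scatter). For compound 3 the expected value is 3000 nM, with an estimated range of 900 nM to 10000 nM.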

Compound 3, half-maximal inhibitory concentration: 12300 nM
For compound 3 the middle estimate is 4.1-fold (0.61 log units) below the measured one; the measured number lies above the stated range.
By their numbers in this assay, from the lowest: compound 2; then compounds 1 and 3 (each within the scatter of the next).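

In this assay, putting 3-chloro-4-hydroxyphenyl in place of 3,5-dichlorophenyl gives a 3.2-fold higher number from compound 2 to compound 3 (0.51 log units; beyond the scatter) at this place, so the position does respond to a change that removes one chlorine and brings in a hydroxyl group. The other new step, a 1.5-fold higher number from compound 1 to compound 3 (0.19 log units; within the scatter) and so no real difference, shows that 3-chloro-4-hydroxyphenyl and 2-methoxyphenyl cannot be told apart here, and the low number of compound 2 remains tied to 3,5-dichlorophenyl among these three compounds. Nothing measured alongside these numbers accounts for the result.

The compounds shown do not separate the effect of losing a chlorine from that of gaining a hydroxyl group. From the compounds shown here alone, how an amine or a carboxylic acid on this ring would behave also stays open.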